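Chloro in place of trifluoromethyl at the assay limit

This account rests on a few compounds, and the source may have more. Where it says the series, first, only, none or still open, it means among the compounds named here.

In a functional assay on the whole organism for inhibition, with Chlorella salina as the target (on this read-out higher numbers stand for weaker inhibition and lower numbers for stronger inhibition), compound 3 (`CC(Cl)/C=C/C(=O)N(Cc1ccc(C(F)(F)F)cc1)CC(C)C`) returns no number, only a limit of > 50100 nM. Compound 4 (`CC(Cl)/C=C/C(=O)N(Cc1ccc(Cl)cc1)CC(C)C`) differs from it in one place: chloro in place of trifluoromethyl on an aromatic carbon.

Two measured compounds bear on this change. Compound 1 (`CC(Cl)/C=C/C(=O)N(Cc1ccc(C#N)cc1)CC(C)C`) gives 3160 nM in this assay. Replacing its cyano with trifluoromethyl produces an at least 15-fold higher number from compound 1 to compound 3 (1.20 log units; beyond the scatter), a large step showing that the group on this aromatic carbon can shift the read-out strongly. Compound 2 (`CC(Br)/C=C/C(=O)N(Cc1ccc(Cl)cc1)CC(C)C`), which also carries chloro on the aromatic carbon, gives 10000 nM.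

With that value from compound 2 as the closest guide, a large step toward a lower number, meaning stronger inhibition, is expected. The expected change is an at least 5.0-fold lower number from compound 3 to compound 4 (0.69 log units; beyond the scatter). For compound 4 the estimated value is 10000 nM, with an expected range of 3000 nM to 35000 nM.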

Compound 4, half-maximal inhibitory concentration: 6310 nM
Beside the measured number, compound 4's estimate is 1.6-fold (0.20 log units) above it, within the range that was stated.
By their numbers in this assay, from the lowest: compounds 1, 4 and 2 (each within the scatter of the next, the first and the last beyond it). At a limit, above all of these: compound 3.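

In this assay, compound 3 carries trifluoromethyl on the aromatic carbon and has only a limit: the limit of > 50100 nM in this assay, at which 1 of the 4 values shown sits. Chloro in place of trifluoromethyl at this carbon gives an at least 7.9-fold lower number from compound 3 to compound 4 (0.89 log units; beyond the scatter) and so brings the read-out back to a measured number. Chloro and cyano at this carbon cannot be told apart, with a 2.0-fold higher number from compound 1 to compound 4 (0.30 log units; within the scatter) and within the scatter, and chloro in place of bromo on the chain carbon is also within the scatter at a 1.6-fold lower number from compound 2 to compound 4 (0.20 log units; within the scatter) so that, of the three groups shown here, only trifluoromethyl stands apart.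

Going by these compounds, whether fluoro, methoxy or an amine on this aromatic carbon would sit with chloro and cyano or with trifluoromethyl remains open. Also open, on these data alone, is whether bromo on the chain carbon would matter with any ring group other than chloro.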